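The source may report more compounds than this note shows. Statements on the series, on what has been measured and on what is new or still open speak of the compounds shown alone.

Among the measured compounds shown here, in a functional assay on A549 cells (Homo sapiens) for inhibition, read by sulforhodamine B assay, with a stated time of 74 h (on this read-out higher numbers stand for weaker inhibition and lower numbers for stronger inhibition), compound 1 `Cc1ccc(S(=O)(=O)N2C(=O)COC23C=CC(=O)C=C3)cc1` gives 110 nM, the only true number in this small set. The other two compounds sit at the limit of > 10000 nM in this assay, at which 2 of the 3 values shown sit. Compound 2 `O=C1C=CC2(C=C1)OCC(=O)N2S(=O)(=O)c1ccccc1` reads > 10000 nM, which is a limit of the assay and not a number. Compound 3 `Cc1ccc(S(=O)(=O)N2C(=O)C(C)OC23C=CC(=O)C=C3)cc1` reads > 10000 nM, which is also a limit.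

Removing the methyl from the aromatic ring of compound 1 gives an at least 90-fold higher number from compound 1 to compound 2 (1.95 log units; beyond the scatter). Adding a methyl to the saturated ring gives an at least 90-fold higher number from compound 1 to compound 3 (1.95 log units; beyond the scatter). Both single changes are large and beyond the scatter.

Compound 4 `O=C1C=CC2(C=C1)OCC(=O)N2S(=O)(=O)c1ccc(N2CCCC2=O)cc1` is altered at the same aromatic place as in the first of these steps: 2-oxopyrrolidin-1-yl in place of methyl on an aromatic carbon. In words, this is 2-oxopyrrolidin-1-yl in place of methyl on an aromatic carbon. For the measured compounds named here, no measured step shows what a group of this size does there. The closest guide is an at least 90-fold higher number from compound 1 to compound 2 (1.95 log units; beyond the scatter), so a clearly higher number is expected, though perhaps not one reaching the limit. The expected change is a 14-fold higher number from compound 1 to compound 4 (1.13 log units; beyond the scatter). The estimated value for compound 4 is 1500 nM, with an expected range from 200 nM to 10000 nM.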

Compound 4, half-maximal inhibitory concentration: 5 nM
Compound 4: middle estimate off by 300-fold (2.48 log units), on the high side, outside the stated range (below it).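

The earlier compounds shown here showed only that losing the methyl from this aromatic carbon costs heavily. Compound 4 shows that the position is not tied to methyl: 2-oxopyrrolidin-1-yl, a much larger group that brings its own ring and a hydrogen-bond acceptor, gives a 22-fold lower number from compound 1 to compound 4 (1.34 log units; beyond the scatter), and with hydrogen at the same place as the starting point it gives an at least 2000-fold lower number from compound 2 to compound 4 (3.30 log units; beyond the scatter). That second step is a bound and not an exact size, since compound 2 sits at a limit of the assay: the limit of > 10000 nM in this assay, at which 2 of the 4 values shown sit.

With a single large group at this place, the compounds shown cannot separate the part played by the ring, the carbonyl or the overall size of the group. They also leave open what an open-chain amide, a simple amine or a carboxylic acid would do on this aromatic carbon.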